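The source may hold more compounds than are shown below. What is called first, only, known or untested is meant among the compounds shown, and "the series" means these compounds.

Measured in an ADME assay on HepG2 cells (Homo sapiens) for cytotoxicity; on this read-out higher numbers stand for lower toxicity in this test and lower numbers for higher toxicity in this test:
- compound 1 `O=C(NC/C=C/S(=O)(=O)c1ccccc1)c1cccc2cccnc12`: 55500 nM
- compound 2 `CC1=CC(C)(C)Nc2c(C(=O)N[C@H](/C=C/S(=O)(=O)c3ccccc3)CCc3ccccc3)cccc21`: > 300000 nM, a limit of the assay
- compound 3 `O=C(N[C@H](/C=C/S(=O)(=O)c1ccccc1)CCc1ccccc1)c1cccc2c1NCCC2`: > 160000 nM, a limit of the assay

Compound 3 stands at > 160000 nM, which is a limit and not a number. Compound 2 likewise gives only a limit, > 300000 nM. Compound 1 alone has a numerical value, 55500 nM.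

Compound 4 `O=C(N[C@H](/C=C/S(=O)(=O)c1ccccc1)CCc1ccccc1)c1ccc([N+](=O)[O-])s1` has not yet been measured in this assay. It differs from compound 3 by one change: 5-nitrothiophen-2-yl in place of 1,2,3,4-tetrahydroquinolin-8-yl on a carbonyl carbon. Here 5-nitrothiophen-2-yl takes the place of 1,2,3,4-tetrahydroquinolin-8-yl on a carbonyl carbon. Among the measured compounds shown here, no step between measured compounds offers a direct guide, so the expectation rests on compound 1 at 55500 nM, the only numerical reading available. A downward move beyond the usual scatter, toward higher toxicity in this test, is expected, and the estimated step is an at least 3.2-fold lower number from compound 3 to compound 4 (0.50 log units; beyond the scatter). For compound 4 the estimated value is 50000 nM, with an expected range from 12000 nM to 200000 nM.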

Compound 4, half-maximal cytotoxic concentration: 12400 nM
Beside the measured number, compound 4's estimate is 4.0-fold (0.61 log units) above it, within the range that was stated.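

In this assay, placing 5-nitrothiophen-2-yl instead of 1,2,3,4-tetrahydroquinolin-8-yl on the carbonyl carbon gives an at least 12-fold lower number from compound 3 to compound 4 (1.11 log units; beyond the scatter), so a change at this place alone can shift the read-out well beyond the scatter, toward higher toxicity in this test. The earlier compounds shown here offered no pair differing in one place, and so could not show this place acting by itself. Compound 3 gives a limit and not a number, so the step gives only the least size of the shift: the limit of > 160000 nM in this assay, at which 1 of the 4 values shown sits.

The compounds shown cannot tell whether the shift belongs to the nitro group or to the thiophene ring that carries it. An amine in place of the nitro group, or a plain phenyl in place of the whole 5-nitrothiophen-2-yl, would separate the two.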